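The compounds below may be only part of what the source reports. "The series", "measured", "known", "first", "only" and "open" are said of these compounds alone.

In an assay on NK92 cells for inhibition of interleukin-2 (Homo sapiens), read by AlphaScreen, with stated times of 30 min and 1 h (on this read-out lower numbers stand for stronger inhibition and higher numbers for weaker inhibition), compound 1 `Cn1c(Cc2nn(C)c(=O)c3ccccc23)nnc1SCCCCCCCC(=O)Nc1ccc(Cl)cc1Cl` gives 350 nM. Compound 2 `Cn1nc(Cc2nnc(SCCCCCCCC(=O)Nc3ccc(Cl)cc3Cl)n2CCCO[Si](C)(C)C(C)(C)C)c2ccccc2c1=O` reaches only the limit of this assay, > 30000 nM. Compound 3 `CN(C)CCCn1c(Cc2nn(C)c(=O)c3ccccc23)nnc1SCCCCCCCC(=O)Nc1ccc(Cl)cc1Cl` likewise stands at a limit in this assay, > 30000 nM, so only a limit is known for it, as the limit of > 30000 nM in this assay, at which 2 of the 3 values shown sit, records. The steps of an at least 85-fold higher number from compound 1 to compound 2 (1.93 log units; beyond the scatter) and an at least 85-fold higher number from compound 1 to compound 3 (1.93 log units; beyond the scatter) were both large losses, while a step that the two limits leave unreadable from compound 2 to compound 3 cannot be read. Compound 4 `Cn1nc(Cc2nnc(SCCCCCCCC(=O)Nc3ccc(Cl)cc3Cl)n2CCC(=O)O)c2ccccc2c1=O` differs from compound 3 by carboxy in place of (dimethylamino)methyl on a saturated chain carbon, two bonds along the chain from an aromatic nitrogen. Both measured departures from the methyl of compound 1 lost activity, and nothing measured shows a carboxy restoring it. The step from compound 3 is therefore expected to read a number no higher from compound 3 to compound 4 (the limit leaves the size open). The estimate for compound 4 in this assay is 30000 nM, with a range from 5000 nM to 100000 nM.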

Compound 4, half-maximal inhibitory concentration: 14300 nM
Compound 4: middle estimate off by 2.1-fold (0.32 log units), on the high side; measured number inside the range.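

In this assay, going by these compounds alone, the 2-carboxyethyl group of compound 4 gives the first readable number for a chain longer than the methyl of compound 1 at this position, yet it still shows a 41-fold higher number from compound 1 to compound 4 (1.61 log units; beyond the scatter). The acid chain also reads better than the other two chains, with an at least 2.0-fold lower number from compound 3 to compound 4 (0.32 log units; beyond the scatter) and an at least 2.0-fold lower number from compound 2 to compound 4 (0.32 log units; beyond the scatter). Compound 2 and compound 3 stand at a limit, so these two steps give only a minimum: the limit of > 30000 nM in this assay, at which 2 of the 4 values shown sit.

Going by these compounds, whether a shorter carboxymethyl chain, a methyl ester or a primary alcohol on this chain would come closer to compound 1 remains open. Also open, on these data alone, is how much of the remaining loss follows the chain length and how much the carboxylic acid itself.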